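From a Long Chain to an Ethynyl End

The source may hold more compounds than are shown below. What is called first, only, known or untested is meant among the compounds shown, and "the series" means these compounds.

Measured so far in a functional assay on HEL cells (Homo sapiens) for cytotoxicity; a lower number here means that less compound is tolerated, a higher number that more compound is tolerated:
Compound 1 `CCCCCCCCc1cc2cn([C@H]3C[C@H](O)[C@@H](CO)O3)c(=O)nc2o1`: > 50000 nM
Compound 2 `CCCCCCCCCCc1cc2cn([C@H]3C[C@H](O)[C@@H](CO)O3)c(=O)nc2o1`: > 50000 nM

Both entries are limits of the assay, not numbers. Compound 2 therefore has no exact value, only its limit of > 50000 nM.

Compound 3 `C#CCCCc1cc2cn([C@H]3C[C@H](O)[C@@H](CO)O3)c(=O)nc2o1` has not yet been measured. It differs from compound 2 in its side chain: ethynyl in place of heptyl on a saturated chain carbon, three bonds along the chain from an aromatic carbon. Among the measured compounds shown here, the only measured step that bears on this change is the lengthening of the chain a step that the two limits leave unreadable from compound 1 to compound 2. Its size cannot be read, and the limit of > 50000 nM in this assay, at which 2 of the 2 values shown sit, shows both compounds sitting at the same limit. The data thus offer no sign of a change in either direction, and compound 3 is expected to remain near that limit, where this assay may again report only a limit. The expected step of a number no higher from compound 2 to compound 3 (the limit leaves the size open) is none beyond the usual scatter. For compound 3 the estimate is 50000 nM, with an expected range of 20000 nM to 100000 nM.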

Compound 3, half-maximal cytotoxic concentration: > 200000 nM
Compound 3 gave a limit, no number (the forecaster's own chance of this, stated with the estimate: 80%); at least 4.0-fold (0.60 log units) between middle value and limit.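

Among the compounds shown here, compound 1, compound 2 and compound 3 all give limits rather than numbers in this assay, so no step among them can be read. The compounds shown leave open whether swapping heptyl for ethynyl changes cytotoxicity, and at what concentration any of the three becomes toxic.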